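The source may report more compounds than this note shows. Statements on the series, on what has been measured and on what is new or still open speak of the compounds shown alone.

Of the compounds shown here, two built on the same core have been tested in a functional assay on HeLa cells (Homo sapiens) for cytotoxicity, read by MTT assay; on this read-out lower numbers stand for stronger inhibition and higher numbers for weaker inhibition. Compound 1, with the structure `CC1=NNC(=O)C1C(c1c(-c2ccccc2)[nH]c2ccccc12)c1c(-c2ccccc2)[nH]c2ccc(Cl)cc12`, gives 29800 nM in this assay. Compound 2, with the structure `CC1=NNC(=O)C1C(c1c[nH]c2ccccc12)c1c(-c2ccccc2)[nH]c2ccc(C)cc12`, gives 2400 nM in this assay. Of these two numbers, compound 2 has the lower one, and its gap to compound 1 lies beyond the usual scatter of repeated measurements, so compound 2 is the more potent of the pair.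

Compound 3, with the structure `CC1=NNC(=O)C1C(c1c[nH]c2ccccc12)c1c(-c2ccccc2)[nH]c2ccc(Cl)cc12`, has not yet been measured. It differs from compound 2 in a single place: chloro in place of methyl on an aromatic carbon. Within the data shown here, no measured pair in this set shows what this particular swap does in this assay, so the expectation rests on the small size of the change alone. The step of a 1.3-fold higher number from compound 2 to compound 3 (0.10 log units; within the scatter) is expected to be small, with no clear direction, and to stay within the scatter. Compound 3 is therefore expected to give about 3000 nM in this assay, within a range from 1200 nM to 8000 nM.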

Compound 3, half-maximal inhibitory concentration: 3800 nM
Compound 3: the middle estimate sits 1.3-fold (0.10 log units) below what was measured; the measured number falls inside the stated range.
By their numbers in this assay, from the lowest: compounds 2 and 3 (each within the scatter of the next); then compound 1.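

In this assay, putting chloro in place of methyl on an aromatic carbon of the six-membered ring gives a 1.6-fold higher number from compound 2 to compound 3 (0.20 log units; within the scatter), so on this read-out the two groups cannot be told apart at this position. Among these compounds, compound 3 also gives the first comparison with compound 1 that differs in one place only: with hydrogen in place of phenyl on an aromatic carbon, the step is a 7.8-fold lower number from compound 1 to compound 3 (0.89 log units; beyond the scatter), and most of the earlier gap between compound 1 and compound 2 therefore goes with the phenyl-to-hydrogen change rather than with the chloro-to-methyl change. Nothing in the data given explains why either step has the size it has.

As far as these compounds go, what a methoxy group, an amine or a carboxylic acid would do on the aromatic carbon that carries methyl or chloro remains open, since only those two groups can be compared there. Also open is whether the phenyl-to-hydrogen step would keep its size with methyl on that carbon, since the compounds shown offer this step only with chloro.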